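The compounds below may be only part of what the source reports. "The series", "measured", "known", "first", "only" and "open" are said of these compounds alone.

Measured in an ADME assay on MT4 cells (Homo sapiens) for cytotoxicity, read by MTT assay, with a stated time of 5 days (a lower number here means that less compound is tolerated, a higher number that more compound is tolerated), so far:
- compound 1 `CC(C)NC(c1ccc(/C=C/C#N)cc1)c1ccnc(Nc2ccc(C#N)cc2)n1` gives 32300 nM as a number
- compound 2 `CC(O)CNC(c1ccc(C#N)cc1)c1ccnc(Nc2ccc(C#N)cc2)n1` gives > 65000 nM as a limit

For compound 2 there is only the limit of > 65000 nM in this assay, at which 1 of the 2 values shown sits, and no number to place it by.

Compound 3 `CC(C)NC(c1ccc(C#N)cc1)c1ccnc(Nc2ccc(C#N)cc2)n1` is not yet measured. It carries isopropyl in place of 2-hydroxypropyl on an amine nitrogen and the rest of compound 2 stays unchanged. Within the data shown here, no measured pair isolates this change, so the expectation rests on little. Isopropyl on the amine nitrogen also occurs in compound 1, which gives 32300 nM and serves as the only numeric guide. A modest move towards less compound tolerated is expected in this assay and the expected size is an at least 1.6-fold lower number from compound 2 to compound 3 (0.21 log units; that floor lies within the scatter) with a real chance of no number at all. Compound 3 is estimated at 40000 nM with an expected range of 17000 nM to 65000 nM for the coming measurement.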

Compound 3, half-maximal cytotoxic concentration: 69200 nM
Compound 3: the middle estimate sits 1.7-fold (0.24 log units) below what was measured; the whole stated range lies below it.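

In this assay, cyano in place of 2-cyanoethenyl on an aromatic carbon, with isopropyl kept on the amine nitrogen, gives a 2.1-fold higher number from compound 1 to compound 3 (0.33 log units; beyond the scatter). Among these compounds, this is the first readable step, and it places the change at the aromatic carbon, not the amine nitrogen, as one that moves this read-out beyond the scatter, though only modestly and in a single pair. Compound 2 carries only a limit, so its step to compound 3 cannot be read: the limit of > 65000 nM in this assay, at which 1 of the 3 values shown sits.

Going by these compounds, whether 2-hydroxypropyl and isopropyl on the amine nitrogen differ at all in this read-out stays open. Also open, on these data alone, is how a longer chain or a cyclopropyl group on that nitrogen, or a longer unsaturated chain on the aromatic carbon, would behave.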